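This account rests on a few compounds, and the source may have more. Where it says the series, first, only, none or still open, it means among the compounds named here.

Measured so far in a functional assay on Jurkat cells (Homo sapiens) for cytotoxicity, with a stated time of 72 h; a lower number here means that less compound is needed, a higher number that more compound is needed for the effect:
- Compound 1 `C=C[C@@](C)(/C=C/c1ccc(O)cc1)CC/C=C/C(=O)OCC`: > 49000 nM
- Compound 2 `C=C[C@@](C)(/C=C/c1ccc(O)cc1)CC/C=C(\C)C=O`: > 49000 nM
- Compound 3 `C=C[C@@](C)(/C=C/c1ccc(O)cc1)CC/C=C(\C)CO`: > 49000 nM

Compound 3 stands at > 49000 nM, which is a limit and not a number. The same holds across the series: the limit of > 49000 nM in this assay, at which 3 of the 3 values shown sit.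

The next compound is compound 4 `C=C[C@@](C)(/C=C/c1ccc(O)cc1)CC/C=C(C)/C=C/C(=O)OCC`. The change is 2-(ethoxycarbonyl)ethenyl in place of hydroxymethyl on a double-bonded chain carbon bound to a double-bonded chain carbon and a saturated chain carbon.

Among the measured compounds shown here, three measured steps bear on it: a step that the two limits leave unreadable from compound 1 to compound 2, a step that the two limits leave unreadable from compound 1 to compound 3 and a step that the two limits leave unreadable from compound 2 to compound 3. None of them has a readable size, so they give no direction for the new change. Compound 1 also carries 2-(ethoxycarbonyl)ethenyl, and its > 49000 nM is likewise a limit.

No step beyond the scatter is therefore expected in this assay. The estimated step is a step that the limit leaves unreadable from compound 3 to compound 4. For compound 4 the estimated value is 50000 nM, with an expected range of 20000 nM to 100000 nM. A report as a limit again is the likeliest outcome.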

Compound 4, half-maximal effective concentration: > 49000 nM
Compound 4: no number, only a limit (the forecaster's own chance of this, stated with the estimate: 70%); the middle value lies beyond the limit too.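

In this assay compound 4 gives > 49000 nM, which is a limit and not a number. Among the compounds shown here, no step from compound 2 or compound 3 to compound 4 can be read. The compounds shown leave open how large any of these changes is: the limit of > 49000 nM in this assay, at which 4 of the 4 values shown sit.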